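The source may hold more compounds than are shown below. What is called first, only, known or untested is meant among the compounds shown, and "the series" means these compounds.

Measured compounds:
- compound 1, `CC(=O)N1CCN(C(=O)Cn2c(-c3ccc(C)cc3)csc2=N)CC1`: 1640 nM
- compound 2, `Cc1ccc(-c2csc(=N)n2CC(=O)N2CCOCC2)cc1`: 3560 nM
- compound 3, `CC(=O)N1CCN(C(=O)Cn2c(-c3ccc(Cl)cc3)csc2=N)CC1`: 607 nM

All three were tested in an assay on isolated protein for inhibition of leukotriene A-4 hydrolase (Homo sapiens); on this read-out higher numbers stand for weaker inhibition and lower numbers for stronger inhibition. Compound 1 and compound 3 share one core, and the only difference between them is the change (chloro in place of methyl on an aromatic carbon). That single change gave a 2.7-fold lower number from compound 1 to compound 3 (0.43 log units; beyond the scatter). Compound 2 carries a different core; how its core differs from that of compound 1 is not broken down here. In this assay compound 2 gives 3560 nM, the highest of the three numbers, and its gap to compound 1 and to compound 3 lies beyond the usual scatter in both cases.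

Compound 4, `N=c1scc(-c2ccc(Cl)cc2)n1CC(=O)N1CCOCC1`, has not yet been measured. It stands to compound 2 as compound 3 stands to compound 1: the change is chloro in place of methyl on an aromatic carbon, the same change at the same kind of place, the two place descriptions reading the same word for word. For the measured compounds named here, since the only measured example of this change is the step from compound 1 to compound 3, the expectation for compound 4 rests on that step alone, a single pair, and the core of compound 2 may respond differently. On that basis the step from compound 2 to compound 4 is estimated at a 2.7-fold lower number from compound 2 to compound 4 (0.44 log units; beyond the scatter). For compound 4 in this assay the estimate is 1300 nM, with a plausible range from 550 nM to 3000 nM.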

Compound 4, inhibition constant: 1060 nM
The estimate for compound 4 lay 1.2-fold (0.09 log units) above the measured number; the measured number falls inside the stated range.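

Putting chloro in place of methyl on the aromatic ring gave a 3.4-fold lower number from compound 2 to compound 4 (0.53 log units; beyond the scatter) in this assay, so a lower number, meaning stronger inhibition, appeared on the core of compound 2 as well. Set beside the earlier example, the two steps agree: the same change on two cores in this assay, a 2.7-fold lower number (0.43 log units; beyond the scatter) from compound 1 to compound 3 and a 3.4-fold lower number (0.53 log units; beyond the scatter) from compound 2 to compound 4, 1.2-fold (0.09 log units) apart, within the scatter of two such steps. This shows that the change carried over between these two cores with much the same size, but it rests on just two pairs, so it does not show that the change would carry over to a third core, and it does not explain why chloro gives the lower number.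

The compounds shown cover only methyl and chloro at this place, so it remains open whether fluoro, methoxy or a carboxylic acid there would give a higher or a lower number than either of them. From the compounds shown here alone, it also remains open whether the step from 4-methylphenyl to 4-chlorophenyl would keep its size on a core carrying an amine or a longer chain.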